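The compounds below may be only part of what the source reports. "The series", "measured", "known", "first", "only" and "open" are said of these compounds alone.

Measured compounds:
- compound 1 `COc1cc(-c2nc(SCc3cn(CC(=O)NC(=O)Nc4ccccn4)nn3)nc(Nc3ccc(C(C)C)cc3)c2C#N)cc(OC)c1OC`: 35500 nM
- compound 2 `COc1cc(-c2nc(SCc3cn(CC(=O)NC(=O)Nc4ccccn4)nn3)nc(Nc3ccc(Cl)cc3)c2C#N)cc(OC)c1OC`: 17500 nM

In a functional assay on MGC-803 cells (Homo sapiens) for inhibition, read by MTT assay, with a stated time of 72 h (on this read-out lower numbers stand for stronger inhibition and higher numbers for weaker inhibition), compound 1 gives 35500 nM and compound 2 gives 17500 nM. Among the compounds with values here, compound 1 therefore carries the highest of the two numbers; the single measured step, a 2.0-fold lower number from compound 1 to compound 2 (0.31 log units; beyond the scatter), puts chloro in place of isopropyl on the (4-isopropylphenyl)amino group and is the only comparison available.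

Compound 3 `CC(C)c1ccc(Nc2nc(SCc3cn(CC(=O)NC(=O)Nc4ccccn4)nn3)nc(-c3ccc(Br)cc3)c2C#N)cc1` differs from compound 1 at another site: 4-bromophenyl in place of 3,4,5-trimethoxyphenyl on an aromatic carbon. The isopropyl on the anilino ring is kept, so the step from compound 1 to compound 2 does not touch the part of the core that is changed here and offers no guide to direction or size. From the compounds shown here alone, the 3,4,5-trimethoxyphenyl to 4-bromophenyl exchange removes three hydrogen-bond acceptors and five heavy atoms, a larger change than any step measured so far, and its effect in this assay is unknown.

With nothing in the measured pair bearing on it, no step beyond the scatter is expected in this assay, a 1.0-fold lower number from compound 1 to compound 3 (0.01 log units; within the scatter), but the range must be wide. Compound 3 is estimated at 35000 nM, between 9000 nM and 130000 nM.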

Compound 3, half-maximal inhibitory concentration: 15600 nM
Compound 3: the middle estimate sits 2.2-fold (0.35 log units) above what was measured; low and high end bracket the measured number.
By their numbers in this assay, from the lowest: compounds 3 and 2 (each within the scatter of the next); then compound 1.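

In this assay, the aryl group on the aromatic carbon opposite the ring nitrogen can be changed without loss, and the exchange of 3,4,5-trimethoxyphenyl for 4-bromophenyl gives a 2.3-fold lower number from compound 1 to compound 3 (0.36 log units; beyond the scatter). The series therefore does not depend on the 3,4,5-trimethoxyphenyl group here, at least with the (4-isopropylphenyl)amino group in place: the number falls, modestly, although the entering group has 0 hydrogen-bond acceptors against 3 for the leaving one, and fewer heavy atoms. This shows that a second site on the shared core, besides the anilino ring, can move the read-out, but nothing available explains the direction of this step.

Because one exchange removes all the methoxy groups and adds bromine, the compounds shown cannot separate the two changes, and unsubstituted phenyl, 4-methoxyphenyl or 4-chlorophenyl at this position would be needed to tell them apart. From the compounds shown here alone, it also remains open whether this step and the chloro-for-isopropyl step on the anilino ring add up, which a compound carrying both 4-bromophenyl and the 4-chloroanilino group would test.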